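The source may hold more compounds than are shown below. What is called first, only, known or untested is meant among the compounds shown, and "the series" means these compounds.

In a functional assay (strain AB) with Danio rerio as the target, read by microscopy, with a stated time of 1 h (on this read-out higher numbers stand for an effect only at larger amounts of compound and lower numbers for an effect already at smaller amounts), compound 3 `CC(C)(C)OC(=O)CCN1CCc2c(sc(NC(=O)Nc3ccc(Cl)cc3)c2C(N)=O)C1` gives 1100 nM and compound 1 `NC(=O)c1c(NC(=O)Nc2ccc(Cl)cc2)sc2c1CCN(CC1CCC1)C2` gives 1360 nM, which is a 1.2-fold lower number from compound 1 to compound 3 (0.09 log units; within the scatter). Compound 2 `CC(C)(C)OC(=O)N1CCc2c(sc(NC(=O)Nc3ccc(Cl)cc3)c2C(N)=O)C1` gives only a limit, > 25000 nM. Compound 4 `NC(=O)c1c(NC(=O)Nc2ccc(Cl)cc2)sc2c1CCN(CC1CCCC1)C2` differs from compound 3 by cyclopentyl in place of (tert-butoxycarbonyl)methyl on a saturated chain carbon bound to an amine nitrogen in a ring, with cyclopentyl in place of (tert-butoxycarbonyl)methyl on a saturated chain carbon bound to an amine nitrogen in a ring. The closest guide is the swap at this place, a 1.2-fold lower number from compound 1 to compound 3 (0.09 log units; within the scatter). The large steps of an at least 18-fold higher number from compound 1 to compound 2 (1.26 log units; beyond the scatter) and an at least 22-fold lower number from compound 2 to compound 3 (1.35 log units; beyond the scatter) both run through compound 2, whose tert-butoxycarbonyl sits on the amine nitrogen itself, and compound 4 lacks that feature. The expected size is therefore no change beyond the scatter, a 1.1-fold higher number from compound 3 to compound 4 (0.04 log units; within the scatter). For compound 4 the estimated value is 1200 nM, with an expected range of 500 nM to 3000 nM.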

Compound 4, half-maximal effective concentration: 1830 nM
Compound 4: the middle estimate sits 1.5-fold (0.18 log units) below what was measured, within the range that was stated.
By their numbers in this assay, from the lowest: compounds 3, 1 and 4 (each within the scatter of the next). At a limit, above all of these: compound 2.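

At this place, on a saturated chain carbon bound to an amine nitrogen in a ring, a 1.7-fold higher number from compound 3 to compound 4 (0.22 log units; within the scatter) and a 1.3-fold higher number from compound 1 to compound 4 (0.13 log units; within the scatter) in this assay show that cyclopentyl reads the same as (tert-butoxycarbonyl)methyl and cyclobutyl. With cyclopentylmethyl in place of tert-butoxycarbonyl on the amine nitrogen, an at least 13-fold lower number from compound 2 to compound 4 (1.13 log units; beyond the scatter) is a third large step through compound 2. Compound 2 gives only a limit: the limit of > 25000 nM in this assay, at which 1 of the 4 values shown sits. On these data alone, whether an amine, a carboxylic acid or a longer chain at this place would move the number beyond the scatter stays open.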